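The compounds below may be only part of what the source reports. "The series", "measured", "known", "first", "only" and "open" are said of these compounds alone.

Measured so far:
compound 1 `CCCCNc1cc(C)nc2c(-c3ccc(Cl)cc3Cl)nn(C)c12` — 170 nM
compound 2 `CCN(CCCOC)c1cc(C)nc2c(-c3ccc(Cl)cc3Cl)nn(C)c12` — 12.5 nM

In an assay on HEK293 cells for displacement of a labelled ligand from corticotropin-releasing factor receptor 1 (Homo sapiens) (a lower number here means a stronger inhibitor, a higher number a weaker inhibitor), compound 1 gives 170 nM, the higher of the two numbers; compound 2 gives 12.5 nM. Within the data shown here, the single measured step is a 14-fold lower number from compound 1 to compound 2 (1.13 log units; beyond the scatter). In that step the hydrogen on the amine nitrogen of compound 1 is lost and the nitrogen ends up carrying ethyl and 3-methoxypropyl chains instead of butyl.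

Compound 3 `CCCCN(CC1CCCN1C)c1cc(C)nc2c(-c3ccc(Cl)cc3Cl)nn(C)c12` is not yet measured; its difference from compound 1 is (1-methylpyrrolidin-2-yl)methyl in place of hydrogen on a nitrogen on an aromatic ring. Here too the hydrogen on the nitrogen is replaced by a carbon substituent, while the butyl chain stays in place; the entering group carries a ring rather than an open chain. Among the measured compounds shown here, the one step that bears on this change is large and toward a lower number, so a step in the same direction, though possibly smaller, is expected. Compound 3 is expected at 30 nM, range 8 nM to 110 nM, which means an expected step of a 5.7-fold lower number from compound 1 to compound 3 (0.75 log units; beyond the scatter).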

Compound 3, inhibition constant: 380 nM
Compound 3: the middle estimate sits 13-fold (1.10 log units) below what was measured, outside the stated range (above it).
By their numbers in this assay, from the lowest: compound 2; then compound 1; then compound 3.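

Replacing the hydrogen on the nitrogen on the aromatic ring does not by itself give a lower number: with butyl kept and (1-methylpyrrolidin-2-yl)methyl entering, this assay shows a 2.2-fold higher number from compound 1 to compound 3 (0.35 log units; beyond the scatter). The earlier 14-fold lower number from compound 1 to compound 2 (1.13 log units; beyond the scatter) therefore cannot be read as a general gain from substitution at this nitrogen; across these compounds, the direction depends on the groups that end up there. No available evidence accounts for the opposite directions of the two steps.

The compounds shown leave open whether the outcome for compound 3 follows from the retained butyl chain, the five-membered ring or the nitrogen within that ring. Cyclopentylmethyl, a carbon-only ring, on the same butyl-bearing nitrogen would help separate the contribution of the ring from that of its nitrogen.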